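Halogen Exchange on the Indole Ring of a Staurosporine-like Series

The source may hold more compounds than are shown below. What is called first, only, known or untested is meant among the compounds shown, and "the series" means these compounds.

Compound 1 `CO[C@@H]1[C@H](N(C)c2ncc(-c3c[nH]c4ccccc34)s2)C[C@H]2O[C@]1(C)n1c3ccccc3c3c4c(c5c6cc(Cl)ccc6n2c5c31)C(=O)NC4` carries a chloro group on the shared core; compound 2 `CO[C@@H]1[C@H](N(C)c2ncc(-c3c[nH]c4ccccc34)s2)C[C@H]2O[C@]1(C)n1c3ccccc3c3c4c(c5c6cc(Br)ccc6n2c5c31)C(=O)NC4` replaces it with bromo, the change read as bromo in place of chloro on an aromatic carbon. Compound 3 `CO[C@@H]1[C@H](N(C)c2ncc(-c3c[nH]c4ccc(Cl)cc34)s2)C[C@H]2O[C@]1(C)n1c3ccccc3c3c4c(c5c6cc(Br)ccc6n2c5c31)C(=O)NC4` adds a chloro to the indole ring of compound 2; how the core of compound 3 differs from the core of compound 1 is not broken down here. In a functional assay on HL-60 cells (Homo sapiens) for antiproliferative activity, read by CellTiter-Glo, with a stated time of 72 h (on this read-out lower numbers stand for stronger inhibition and higher numbers for weaker inhibition), compound 1 gives only a limit, > 10000 nM. Compound 2 likewise gives only a limit, > 10000 nM. Compound 3 also gives only a limit, > 10000 nM. Hence the steps a step that the two limits leave unreadable from compound 1 to compound 2 and a step that the two limits leave unreadable from compound 2 to compound 3 are not readable, as the limit of > 10000 nM in this assay, at which 3 of the 3 values shown sit, shows.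

Compound 4 `CO[C@@H]1[C@H](N(C)c2ncc(-c3c[nH]c4ccc(Br)cc34)s2)C[C@H]2O[C@]1(C)n1c3ccccc3c3c4c(c5c6cc(Br)ccc6n2c5c31)C(=O)NC4` is not yet measured; it differs from compound 3 by bromo in place of chloro on an aromatic carbon. This is the same kind of change as in compound 2, but the place differs: there the ring is part of a fused or bridged system of eight rings, here of two rings. The step from compound 3 to compound 4 in this assay is estimated at a step that the limit leaves unreadable from compound 3 to compound 4, resting on the limit that compound 3 gives, > 10000 nM. Compound 4 is expected to give 15000 nM, most likely again a limit.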

Compound 4, half-maximal inhibitory concentration: > 10000 nM
Compound 4: a limit, no number (the forecaster's own chance of this, stated with the estimate: 85%); the middle value is on the limit's open side.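

In this assay compound 4 gives > 10000 nM, a limit and not a number, so no new step can be read from compound 2 or compound 3 to compound 4: the limit of > 10000 nM in this assay, at which 4 of the 4 values shown sit. Compounds 1 to 4 leave open whether any chloro or bromo exchange shifts antiproliferative activity, as none of them gives a number.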